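A few compounds are considered here, and "the series" means these few. Any claim that something is new, unique, unknown or untested is made for them only; others in the source may bear on it.

In a functional assay on MCF7 cells (Homo sapiens) for inhibition, read by sulforhodamine B assay (on this read-out higher numbers stand for weaker inhibition and lower numbers for stronger inhibition), three compounds on the shared core have results so far. Compound 1 (`O=C1C=C(NC2CCCCC2)C(=O)c2c1nc1n2[C@H]2OC[C@@H](O)[C@H]2OC1`), with cyclohexyl on the amine nitrogen, reads > 8000 nM as a limit of the assay and not a number. With 4-methoxyphenyl in that place, compound 2 (`COc1ccc(NC2=CC(=O)c3nc4n(c3C2=O)[C@H]2OC[C@@H](O)[C@H]2OC4)cc1`) gives 5420 nM on the same read-out. With 4-methylphenyl, compound 3 (`Cc1ccc(NC2=CC(=O)c3nc4n(c3C2=O)[C@H]2OC[C@@H](O)[C@H]2OC4)cc1`) gives 1660 nM as the lowest number of the three.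

Compound 4 (`O=C1C=C(Nc2ccccc2)C(=O)c2c1nc1n2[C@H]2OC[C@@H](O)[C@H]2OC1`) has hydrogen in place of methyl on an aromatic carbon, so 4-methylphenyl becomes phenyl. The closest guide is the change at that same carbon, a modest step of a 3.3-fold lower number from compound 2 to compound 3 (0.51 log units; beyond the scatter) in size. The steps of an at least 1.4-fold lower number from compound 1 to compound 2 (0.16 log units; that floor lies within the scatter) and an at least 4.8-fold lower number from compound 1 to compound 3 (0.68 log units; beyond the scatter) rest on the limit of > 8000 nM in this assay, at which 1 of the 3 values shown sits, and so give only floors. Among the compounds with values here, no measured step puts hydrogen on that carbon, so in this assay a modest rise in the number is expected, of about the size of the step of a 3.3-fold lower number from compound 2 to compound 3 (0.51 log units; beyond the scatter) or smaller. The expected change is a 1.8-fold higher number from compound 3 to compound 4 (0.26 log units; within the scatter) in this estimate. Compound 4 is estimated at 3000 nM (expected range 1200 nM to 7500 nM).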

Compound 4, half-maximal inhibitory concentration: > 4000 nM
Compound 4 gave a limit, no number; the forecaster's own chance of this, stated with the estimate: 12%; at least 1.3-fold (0.12 log units) between middle value and limit.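

In this assay, taking the methyl off the 4-methylphenyl group to leave phenyl gives an at least 2.4-fold higher number from compound 3 to compound 4 (0.38 log units; beyond the scatter). The earlier compounds shown here compared only methyl with methoxy at this carbon, para to a large group; now hydrogen has been tested there too, and it also reads worse than methyl. Among the four compounds, compound 3 alone has steps to all the others that are printed as beyond the scatter, so methyl is the best of the groups compared at this carbon so far.

On these data alone, the steps from compound 2 and from compound 1 to compound 4 cannot be read, so it stays open whether hydrogen or methoxy serves better at this carbon. Also open, as far as these compounds go, is how chlorine, an amine or an ethyl group would read at the same carbon.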